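The source may hold more compounds than are shown below. What is called first, only, known or untested is meant among the compounds shown, and "the series" means these compounds.

Among the compounds with values here, compound 1 `NC1=NC2(CCOCC2)N(OCCCOc2cccc(Cl)c2)C(N)=N1` is the one member of this set with a number: in an assay on isolated protein for inhibition of Dihydrofolate reductase (Homo sapiens), read by spectrophotometry, using NADPH, with stated times of 5 s and 6 min, tested at 50 uM (on this read-out higher numbers stand for a stronger effect at the one concentration tested and lower numbers for a weaker effect), compound 1 gives 85.8%. Compound 2 `NC1=NC2(CCOCC2)N(OCCCOc2ccc(Cl)c(Cl)c2)C(N)=N1` has no result in this assay, compound 2 being reported as "not determined" (no result reported). Compound 3 `NC1=NC2(CCOCC2)N(OCCCOc2ccc(Cl)cc2)C(N)=N1` likewise stands without a single number; for compound 3 this assay reports "not determined" (no result reported), so compound 3 cannot be placed against compound 1, and compound 2 shares the same absence of a number. Compound 4 `NC1=NC2(CCOCC2)N(OCCCOc2ccccc2Br)C(N)=N1` has not been measured. It differs from compound 3 by 2-bromophenyl in place of 4-chlorophenyl on an oxygen on a saturated carbon. No step between measured compounds is shown, so the direction of the change cannot be read from the data, and any step from compound 3 may fall within the scatter. Compound 4 is expected to give about 75% in this assay, within a range of 45% to 95%, resting on the value of compound 1 85.8% as the only number shown.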

Compound 4, a percentage reported as inhibition, at one concentration (the size of the read-out at that concentration, not a potency): 85%
Beside the measured number, compound 4's estimate is 10 percentage points below it; measured number inside the range.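

In this assay, exchanging the 3-chlorophenyl group for a 2-bromophenyl group gives a number 0.8 percentage points lower from compound 1 to compound 4 (within the scatter), so this position now has two aryl groups, differing in halogen and its place on the ring, whose read-outs cannot be told apart. Steps involving compound 2 or compound 3 cannot be read, as neither has a number. No measurement given here accounts for this result.

On these data alone, whether an amine or a carboxylic acid on the ring would hold this read-out stays open. So does the effect of an unsubstituted phenyl at this position.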